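The source may hold more compounds than are shown below. What is called first, only, known or untested is meant among the compounds shown, and "the series" means these compounds.

Compound 1 `COc1ccc(-c2cc(-c3ccc(F)cc3)nc(NC(=O)N/N=C\c3ccc([N+](=O)[O-])cc3)n2)cc1OC`: 300 mg/kg
Compound 2 `C/C(=N/NC(=O)Nc1nc(-c2ccc(F)cc2)cc(-c2ccc([N+](=O)[O-])cc2)n1)c1ccc(C)cc1`: 300 mg/kg
Compound 3 `COc1ccc(-c2cc(-c3ccc(Cl)cc3)nc(NC(=O)N/N=C\c3ccc([N+](=O)[O-])cc3)n2)cc1OC`: 100 mg/kg

The three measured compounds were tested in a functional assay on the whole organism (strain Albino) with Mus musculus as the target, with a stated time of 4 h; on this read-out lower numbers stand for an effect already at smaller amounts and higher numbers for an effect only at larger amounts of compound. Compound 1 gives 300 mg/kg in this assay, and compound 3 gives 100 mg/kg. The two differ in one place only, (chloro in place of fluoro on an aromatic carbon), and this change brings a 3.0-fold lower number from compound 1 to compound 3 (0.48 log units; beyond the scatter).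

Compound 2 gives 300 mg/kg in this assay, the same number as compound 1 at the digits recorded; the two values lie within the usual scatter of each other, so no order between them can be read. Compound 2 and compound 1 are built on different cores, and the difference between the two cores is not broken down here.

Compound 4 `C/C(=N/NC(=O)Nc1nc(-c2ccc(Cl)cc2)cc(-c2ccc([N+](=O)[O-])cc2)n1)c1ccc(C)cc1` has not yet been measured. It stands to compound 2 exactly as compound 3 stands to compound 1: the change is chloro in place of fluoro on an aromatic carbon, the same change at the same place. Among the compounds with values here, because the change from compound 1 to compound 3 brought a 3.0-fold lower number from compound 1 to compound 3 (0.48 log units; beyond the scatter), a step of similar size is expected on the new core as well, a 3.0-fold lower number from compound 2 to compound 4 (0.48 log units; beyond the scatter), though with only one earlier example of the change the step could be somewhat larger or smaller. Starting from compound 2 at 300 mg/kg, compound 4 is estimated to give 100 mg/kg in this assay, expected to fall between 50 mg/kg and 300 mg/kg.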

Compound 4, dose for half-maximal effect: 300 mg/kg
Beside the measured number, compound 4's estimate is 3.0-fold (0.48 log units) below it; measured number inside the range.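

On the second core, changing 4-fluorophenyl to 4-chlorophenyl in this assay brings no change at the digits printed from compound 2 to compound 4 (within the scatter), so the step seen on the first core does not repeat here. Set side by side, the two results differ by more than ordinary measurement scatter would allow: the same change on two cores in this assay, a 3.0-fold lower number (0.48 log units; beyond the scatter) from compound 1 to compound 3 and no change at the digits printed (within the scatter) from compound 2 to compound 4, 3.0-fold (0.48 log units) apart, beyond the scatter of two such steps This shows that, in this series, the step measured on one core cannot simply be carried over to the other, but it does not show what lies behind the difference, since the two cores differ from each other in ways not broken down here, and one pair on each core gives no general rule about which cores will respond.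

The compounds shown carry only fluoro or chloro at this place, so it remains open how a bromo, a methyl or an amine there would read on either core. From the compounds shown here alone, it also remains open whether the step on a third core would resemble the one on the first core, the one on the second, or neither.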